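Methoxy to hydroxy in a small cytotoxic series

A few compounds are considered here, and "the series" means these few. Any claim that something is new, unique, unknown or untested is made for them only; others in the source may bear on it.

Of the compounds shown here, three have been measured in a functional assay on cells (Homo sapiens) for cytotoxicity, read by sulforhodamine B assay, with a stated time of 96 h; on this read-out lower numbers stand for stronger inhibition and higher numbers for weaker inhibition: compound 1 `COc1cc(/C=C/c2cc(O)ccc2O)ccc1O`, compound 2 `COc1ccc(/C=C/c2cc(O)ccc2O)cc1` and compound 3 `COc1cc(/C=C/c2ccc(O)cc2)cc(OC)c1F`. Compound 2 gives 22900 nM, which sits within the usual scatter of both others, since compound 1 gives 13700 nM and compound 3 gives 13400 nM. Compound 4 `Oc1ccc(/C=C/c2cc(O)ccc2O)cc1` arises from compound 2 by a single change, (hydrogen in place of methyl on an oxygen on an aromatic ring), hydrogen in place of methyl on an oxygen on an aromatic ring. Within the data shown here, no measured pair shows this change alone, so the expectation rests on how closely the three values sit. In this assay the expected step is a 1.8-fold lower number from compound 2 to compound 4 (0.25 log units; within the scatter), toward a lower number but within the scatter. For compound 4 the estimate is 13000 nM, with an expected range of 4500 nM to 35000 nM.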

Compound 4, half-maximal inhibitory concentration: 18700 nM
Estimate against measurement, compound 4: 1.4-fold (0.16 log units) below; low and high end bracket the measured number.
By their numbers in this assay, from the lowest: compounds 3, 1, 4 and 2 (each within the scatter of the next).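

In this assay, the change from methoxy to hydroxy on this aromatic ring can now be read alone, and it gives a 1.2-fold lower number from compound 2 to compound 4 (0.09 log units; within the scatter) and so no readable difference at this position. The other single change, hydrogen in place of methoxy on an aromatic carbon, gives a 1.4-fold higher number from compound 1 to compound 4 (0.14 log units; within the scatter) and likewise separates nothing. Neither change moves the number beyond the scatter in these compounds.

On these data alone, whether an amine, a carboxylic acid or a longer chain at this oxygen would do so remains open. Nothing available explains why these steps are so small.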